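The compounds below may be only part of what the source reports. "The series", "measured", "known", "first", "only" and "open" are said of these compounds alone.

In a functional assay for inhibition, with Homo sapiens as the target (a lower number here means tighter binding, a higher number weaker binding), compound 1 (`CC(C)(C)c1ccc(OC(C)(C)C2OCC(C/C=C\CCC(=O)O)C(c3cccnc3)O2)cc1`) gives 1910 nM, compound 2 (`CC(C)(Oc1ccc(F)cc1)C1OCC(C/C=C\CCC(=O)O)C(c2cccnc2)O1`) gives 120 nM and compound 3 (`CSc1ccccc1OC(C)(C)C1OCC(C/C=C\CCC(=O)O)C(c2cccnc2)O1`) gives 89.1 nM. Compound 3 therefore shares the low end of these numbers with compound 2, showing a 1.3-fold lower number from compound 2 to compound 3 (0.13 log units; within the scatter), and stands well clear of compound 1, showing a 21-fold lower number from compound 1 to compound 3 (1.33 log units; beyond the scatter). Compound 4 (`CC(C)(Oc1ccccc1Br)C1OCC(C/C=C\CCC(=O)O)C(c2cccnc2)O1`) has bromo in place of methylsulfanyl on an aromatic carbon, ortho to a large group (bromo in place of methylsulfanyl on an aromatic carbon). Within the data shown here, no measured step makes this exact swap. The closest guide is the change of aryl group in a 1.3-fold lower number from compound 2 to compound 3 (0.13 log units; within the scatter), which stayed within the scatter. The large 16-fold lower number from compound 1 to compound 2 (1.20 log units; beyond the scatter) involves losing tert-butyl, which plays no part here. So this assay is expected to show no step beyond the scatter, an estimated 1.1-fold higher number from compound 3 to compound 4 (0.05 log units; within the scatter). For compound 4 the estimated value is 100 nM, with an expected range of 40 nM to 250 nM.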

Compound 4, dissociation constant: 63.1 nM
For compound 4 the middle estimate is 1.6-fold (0.20 log units) above the measured one; low and high end bracket the measured number.
By their numbers in this assay, from the lowest: compounds 4, 3 and 2 (each within the scatter of the next); then compound 1.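

In this assay, bromo can take the place of methylsulfanyl on this aromatic carbon with no change beyond the scatter, a 1.4-fold lower number from compound 3 to compound 4 (0.15 log units; within the scatter), so one heavy atom does as well here as the two it replaces. The 2-bromophenyl group also stays level with 4-fluorophenyl, a 1.9-fold lower number from compound 2 to compound 4 (0.28 log units; within the scatter), and stands well clear of 4-(tert-butyl)phenyl, a 30-fold lower number from compound 1 to compound 4 (1.48 log units; beyond the scatter). Nothing available explains these results.

Going by these compounds, what an amine or a longer chain on this same aromatic carbon would do remains open.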